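A few compounds are considered here, and "the series" means these few. Any claim that something is new, unique, unknown or untested is made for them only; others in the source may bear on it.

The two compounds measured so far share a core, shown as `C=CC(=O)Oc1cc(C(F)(F)F)cc(C(F)(F)F)c1` for compound 1 and `C=CS(=O)(=O)c1cc(C(F)(F)F)cc(C(F)(F)F)c1` for compound 2. In an ADME assay for pharmacokinetics, read by HPLC, in phosphate buffer, with a stated time of 72 h, at pH 7.4, tested at 250 uM (a lower number here means that the compound disappears faster, a higher number that the compound lasts longer), compound 1 gives only a limit of < 0.017 h. In this assay compound 2 likewise gives only a limit of < 0.017 h. The step that the two limits leave unreadable from compound 1 to compound 2 therefore cannot be read, since (the limit of < 0.017 h in this assay, at which 2 of the 2 values shown sit). Compound 2 thus stands at the limit of this assay, with no number to place it against any other compound. Compound 3, `O=C1C=CC(=O)N1c1cc(C(F)(F)F)cc(C(F)(F)F)c1`, is the next compound to be measured there. It differs from compound 2 by a group of 7 heavy atoms (4 carbon, 1 nitrogen, 2 oxygen; one five-membered non-aromatic ring with 1 hetero atom) in place of a group of 5 heavy atoms (2 carbon, 2 oxygen, 1 sulfur; no ring), on an aromatic carbon. Among the compounds with values here, no measured step bears on this change, and the single step among the measured compounds is itself unreadable, so neither a direction nor a size can be drawn from the data. Compound 3 is nonetheless estimated at 1 h, within 0.017 h to 24 h, in this assay. That estimate is expected to mean a step of an at least 58-fold higher number from compound 2 to compound 3 (1.76 log units; beyond the scatter), held with wide uncertainty.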

Compound 3, half-life: < 0.017 h
Compound 3 was reported as a limit (the forecaster's own chance of this, stated with the estimate: 40%); middle value at least 58-fold (1.76 log units) away from the limit.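

In this assay compound 3 gives only a limit, < 0.017 h. The steps to compound 3 from compound 1 and from compound 2 therefore cannot be read: the limit of < 0.017 h in this assay, at which 3 of the 3 values shown sit.

The compounds shown leave open whether these three differ at all in this assay.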